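The source may hold more compounds than are shown below. What is called first, only, known or untested is meant among the compounds shown, and "the series" means these compounds.

compound 1 `O=C1CSC(N2N=C(c3ccc(Cl)c(Cl)c3)CC2c2ccc(Cl)cc2)=N1` — 187000 nM
compound 2 `O=C1CSC(N2N=C(c3ccc(Cl)c(Cl)c3)CC2c2cccc(Cl)c2)=N1` — 165000 nM
compound 3 `COc1ccc(C2CC(c3ccc(C)c(C)c3)=NN2C2=NC(=O)CS2)cc1` — 387000 nM

In an ADME assay on RAW264.7 cells (Mus musculus) for cytotoxicity, read by MTT assay, with a stated time of 24 h (on this read-out lower numbers stand for higher toxicity in this test and higher numbers for lower toxicity in this test), compound 3 gives the highest number of the three; compound 1 is nearest and compound 2 furthest, both gaps beyond the scatter. Compound 4 `Cc1ccc(C2=NN(C3=NC(=O)CS3)C(c3ccc(Br)cc3)C2)cc1C` differs from compound 3 by bromo in place of methoxy on an aromatic carbon. For the measured compounds named here, the only measured step, a 1.1-fold lower number from compound 1 to compound 2 (0.05 log units; within the scatter), swaps 3-chlorophenyl for 4-chlorophenyl on a saturated ring carbon and is within the scatter, so it bears only loosely on a methoxy-to-bromo exchange. Compounds 1 and 2, which carry a chlorophenyl rather than a methoxyphenyl on that saturated ring carbon, both give lower numbers than compound 3, so a moderately lower number is expected for compound 4, a 1.5-fold lower number from compound 3 to compound 4 (0.19 log units; within the scatter). Compound 4 is estimated at 250000 nM, with a range from 120000 nM to 500000 nM.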

Compound 4, half-maximal cytotoxic concentration: 365000 nM
Estimate against measurement, compound 4: 1.5-fold (0.16 log units) below; measured number inside the range.
By their numbers in this assay, from the lowest: compounds 2, 1, 4 and 3 (each within the scatter of the next, the first and the last beyond it).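

In this assay the change from 4-methoxyphenyl to 4-bromophenyl gives a 1.1-fold lower number from compound 3 to compound 4 (0.03 log units; within the scatter), so no difference can be read between these two groups at this position. The earlier step only moved chloro on the ring, whereas this one replaces the group itself and still stays within the scatter. Nothing on hand accounts for this result.

As far as these compounds go, whether an amine or a carboxylic acid at this position would also leave the number unchanged stays open. So does whether the same exchange would read alike on the core of compound 1.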